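Trifluoromethyl Position Shift on a Dihydro-oxadiazole Series

This account rests on a few compounds, and the source may have more. Where it says the series, first, only, none or still open, it means among the compounds named here.

Measured so far:
compound 1, `COc1ccc(/C=N/NC(=O)c2cc(OC)c(OC)c(OC)c2)c(OC)c1`, 22.2%
compound 2, `COc1cc(C2=NN(C(C)=O)C(c3ccccc3C(F)(F)F)O2)cc(OC)c1OC`, 15.2%
compound 3, `COc1cc(C(=O)N/N=C/c2ccc(Cl)c([N+](=O)[O-])c2)cc(OC)c1OC`, 42.3%

These three compounds were tested in a functional assay on PC-3 cells (Homo sapiens) for antiproliferative activity, read by MTT assay, tested at 5 uM; a higher number here means a stronger effect of the compound at the concentration tested, a lower number a weaker effect. Compound 3 gives 42.3%, compound 1 gives 22.2%, and compound 2 gives 15.2%. Among the three numbers, compound 2's is the lowest, but its gap to compound 1 is within the usual scatter, so the two cannot be told apart; only compound 3 stands beyond the scatter from compound 2.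

Compound 4, `COc1cc(C2=NN(C(C)=O)C(c3ccc(C(F)(F)F)cc3)O2)cc(OC)c1OC`, has not yet been measured in this assay. It differs from compound 2 in one place: 4-(trifluoromethyl)phenyl in place of 2-(trifluoromethyl)phenyl on a saturated ring carbon. The two have the same atoms, joined differently, and the change moves the trifluoromethyl around the phenyl ring on the saturated ring carbon.

Going by the values given here, no pair of measured compounds shows what such a move does, so no step size is known. The step of a number 2.8 percentage points higher from compound 2 to compound 4 (within the scatter) is expected to be small, not clearly beyond the scatter in either direction. Compound 4 is therefore estimated at 18%, with a range from 5% to 35%.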

Compound 4, a percentage reported as inhibition, at one concentration (the size of the read-out at that concentration, not a potency): -0.7%
The estimate for compound 4 lay 18.7 percentage points above the measured number; measured number below the stated range.
By their numbers in this assay, from the lowest: compound 4; then compounds 2 and 1 (each within the scatter of the next); then compound 3.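

In this assay, the place of the trifluoromethyl on the phenyl ring proves to matter on this shared core: putting 4-(trifluoromethyl)phenyl in place of 2-(trifluoromethyl)phenyl on the saturated ring carbon gives a number 15.9 percentage points lower from compound 2 to compound 4 (beyond the scatter). Going by these compounds alone, the two groups hold the same atoms and differ only in how they are joined, and this is the first step that shows the size of such a move. Nothing at hand accounts for the size or direction of this step.

The compounds shown leave open whether moving a nitrile or an amine around the same phenyl ring would give a step of like size. They also leave open whether the step would hold with a longer chain in place of the acetyl group, or at any other concentration.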